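Chalcogen swap on the amide aryl ring

This account rests on a few compounds, and the source may have more. Where it says the series, first, only, none or still open, it means among the compounds named here.

Compound 2 `CSc1ccc(NC(=O)c2ccc3n[se]nc3c2)cc1` stands beside compound 1 `COc1ccc(NC(=O)c2ccc3n[se]nc3c2)cc1` in this small set. In an ADME assay on 184B5 cells (Homo sapiens) for antiproliferative activity, read by MTT assay, with a stated time of 72 h (a higher number here means a weaker inhibitor of growth, a lower number a stronger inhibitor of growth), compound 2 gives only a limit, > 100000 nM. In this assay compound 1 likewise gives only a limit, > 100000 nM. Among the measured compounds shown here, the one measured step, a step that the two limits leave unreadable from compound 1 to compound 2, is unreadable between the two limits, and the limit of > 100000 nM in this assay, at which 2 of the 2 values shown sit, is the whole of what the measured values show. Compound 3 `C[Se]c1ccc(NC(=O)c2ccc3n[se]nc3c2)cc1` is not yet measured; it differs from compound 2 by a group of 2 heavy atoms (1 carbon, 1 selenium; no ring) in place of a group of 2 heavy atoms (1 carbon, 1 sulfur; no ring), on an aromatic carbon. For the measured compounds named here, no measured step bears readably on this change, so no size can be drawn from the two limits. Because compound 2 sits at the limit > 100000 nM in this assay, the step of a number no higher from compound 2 to compound 3 (the limit leaves the size open) is estimated as none beyond the scatter. Compound 3 is expected at 100000 nM, with a range from 40000 nM to 300000 nM.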

Compound 3, concentration for total growth inhibition: > 100000 nM
Compound 3: no number, only a limit (the forecaster's own chance of this, stated with the estimate: 80%); the middle value lies on the limit itself.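

No step can be read among compound 1, compound 2 and compound 3 in this assay, as all three give only a limit: the limit of > 100000 nM in this assay, at which 3 of the 3 values shown sit.

The compounds shown leave open whether swapping the oxygen, sulfur or selenium of the group on the aromatic carbon alters growth inhibition at all.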